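A few compounds are considered here, and "the series" means these few. Any claim that something is new, unique, unknown or untested is made for them only; others in the source may bear on it.

Measured in a functional assay on HeLa cells (Homo sapiens) for antiproliferative activity, read by MTT assay, with a stated time of 3 days; on this read-out lower numbers stand for stronger inhibition and higher numbers for weaker inhibition:
Compound 1 `Cc1ccc(C#Cc2cn(C/C=C\CN3C(=O)c4ccccc4C3=O)c(=O)[nH]c2=O)cc1`: > 100000 nM
Compound 2 `CCCCCCCCC#Cc1cn(C/C=C\CN2C(=O)c3ccccc3C2=O)c(=O)[nH]c1=O`: 59000 nM
Compound 3 `CCCCCC#Cc1cn(C/C=C/CN2C(=O)c3ccccc3C2=O)c(=O)[nH]c1=O`: 91000 nM

The entry for compound 1 is a limit of the assay and not a number. Among the measured compounds shown here, compound 3, at 91000 nM, lies within the scatter of compound 2, at 59000 nM, and these are the only two true numbers in the set.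

The next structure is compound 4 `O=C1c2ccccc2C(=O)N1C/C=C/Cn1cc(C#CCCc2ccccc2)c(=O)[nH]c1=O`. It differs from compound 3 as follows: phenyl in place of propyl on a saturated chain carbon, two bonds along the chain from a triple-bonded carbon.

For the measured compounds named here, only one measured step bears on this change: an at least 1.6-fold lower number from compound 1 to compound 2 (0.22 log units; that floor lies within the scatter). There, octyl takes the place of 4-methylphenyl on a triple-bonded carbon, so a chain replaces an aromatic ring, roughly the reverse of the present change. Its floor lies within the scatter, and it sets no firm size. Read backwards, it points, if anywhere, to a slightly higher number for a ring-bearing group, but the ring here sits further along the chain.

In this assay, no step beyond the scatter is therefore expected. The expected step is a 1.2-fold lower number from compound 3 to compound 4 (0.08 log units; within the scatter). For compound 4 the estimated value is 75000 nM, with an expected range from 30000 nM to 100000 nM.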

Compound 4, half-maximal inhibitory concentration: 29000 nM
Estimate against measurement, compound 4: 2.6-fold (0.41 log units) above, outside the stated range (below it).
By their numbers in this assay, from the lowest: compound 4; then compounds 2 and 3 (each within the scatter of the next). At a limit, above all of these: compound 1.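

In this assay, among the compounds shown here, phenyl in place of propyl on a saturated chain carbon, two bonds along the chain from a triple-bonded carbon, gives a 3.1-fold lower number from compound 3 to compound 4 (0.50 log units; beyond the scatter), the first step in this set that lies beyond the scatter. This shows that the far end of the chain on the triple-bonded carbon is a place where the group matters, which the earlier compounds could not show, as their one listed step set only a floor within the scatter and their two true numbers lay within the scatter of each other. The finding rests on this single pair, and compound 1, which carries 4-methylphenyl on a triple-bonded carbon, goes against any reading that an aromatic ring alone brings a lower number.

The compounds shown leave open whether a longer chain ending in phenyl, or a phenyl ring bearing a methoxy group, an amine or a fluorine, would move the number further. The entry for compound 1 is a limit of the assay and not a number, so the effect of a ring placed directly on the triple-bonded carbon also stays unsized: the limit of > 100000 nM in this assay, at which 1 of the 4 values shown sits.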